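Methoxy on a bis-amidine benzofuran: cytotoxicity expectations

This account rests on a few compounds, and the source may have more. Where it says the series, first, only, none or still open, it means among the compounds named here.

Three related compounds have been tested in an ADME assay on L6 cells (Rattus norvegicus) for cytotoxicity; on this read-out higher numbers stand for weaker inhibition and lower numbers for stronger inhibition. Compound 1 `N=C(N)c1cccc(-c2cc3cc(C(=N)N)ccc3o2)c1` gives 21200 nM. Compound 3 `COc1ccc(C(=N)N)cc1-c1cc2cc(C(=N)N)ccc2o1` gives 179000 nM. Compound 2 `CC(C)NC(=N)c1cccc(-c2cc3ccc(C(=N)NC(C)C)cc3o2)c1` carries isopropyl groups on both amidines, and here the assay reports only a limit, since compound 2 gives > 200000 nM. How the core of compound 2 differs from the core of compound 1 is not broken down here.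

Within the measured pairs, one change has a clear result: methoxy in place of hydrogen on an aromatic carbon, which produced an 8.4-fold higher number from compound 1 to compound 3 (0.93 log units; beyond the scatter). Compound 4 `COc1ccc(C(=N)NC(C)C)cc1-c1cc2ccc(C(=N)NC(C)C)cc2o1` has not yet been measured, and it stands to compound 2 as compound 3 stands to compound 1, through (methoxy in place of hydrogen on an aromatic carbon). The surroundings are not identical: in compound 3 the methoxy sits para to a group of 3 heavy atoms, in compound 4 para to a group of 6 heavy atoms, so this is the same kind of change rather than the same change.

The estimated step that the limit leaves unreadable from compound 2 to compound 4 is set beside the measured one, an 8.4-fold higher number from compound 1 to compound 3 (0.93 log units; beyond the scatter), and rests on that pair, compound 1 and compound 3. Because compound 2 already sits at the limit of > 200000 nM in this assay, at which 1 of the 3 values shown sits, a further rise would most likely leave compound 4 beyond what this assay can report as a number. Compound 4 is therefore expected to give 400000 nM, with a range from 150000 nM to 1500000 nM.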

Compound 4, half-maximal inhibitory concentration: > 175000 nM
Compound 4: a limit, no number; the forecaster's own chance of this, stated with the estimate: 85%; the middle value does not contradict the limit.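

Going by these compounds alone, compound 2 and compound 4 each give only a limit in this assay, not a number, and so no step between them can be read. The compounds shown leave open whether methoxy in place of hydrogen on an aromatic carbon changes the number at all when both amidines carry isopropyl groups, and, if it does, in which direction and by how much.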